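Aryl variation on the shared core: a further analogue

The source may report more compounds than this note shows. Statements on the series, on what has been measured and on what is new or still open speak of the compounds shown alone.

Measured so far in an assay on CHO cells for displacement of a labelled ligand from adenosine receptor A3 (Homo sapiens), read by scintillation counting, tested at 10 uM; on this read-out higher numbers stand for more inhibition at the one concentration tested (going by the name of the read-out) and lower numbers for less inhibition:
- compound 1, `CC(C)(C)Cc1c(-c2cc(F)ccc2F)sc(N)c1C(=O)c1ccc(Cl)cc1`: 1%
- compound 2, `CC(C)(C)Cc1c(-c2c(F)cccc2F)sc(N)c1C(=O)c1ccc(Cl)cc1`: 1%
- compound 3, `COCCOc1ccc(-c2sc(N)c(C(=O)c3ccc(Cl)cc3)c2CC(C)(C)C)cc1`: 1%

Compound 3 stands level with compounds 1 and 2 at the digits shown; none of the three gives inhibition in this assay that rises above the scatter, and the one step available among them, no change at the digits printed from compound 1 to compound 2 (within the scatter), is flat. Compound 4, `CC(C)c1ccc(-c2sc(N)c(C(=O)c3ccc(Cl)cc3)c2CC(C)(C)C)cc1`, differs from compound 3 in a single place: isopropyl in place of 2-methoxyethoxy on an aromatic carbon. Going by the values given here, no measured step exchanges a group of this kind, so nothing bears on the change directly. What the measured compounds do show is that three different substituents on the six-membered aromatic ring of carbon only all gave inhibition within the scatter of one another, compound 3 with 1% among them. The expected step is therefore none beyond the scatter, no change at the digits printed from compound 3 to compound 4 (within the scatter). Compound 4 is expected to give 1%, in the range from -6% to 10%.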

Compound 4, a percentage reported as inhibition, at one concentration (the size of the read-out at that concentration, not a potency): 1%
Beside the measured number, compound 4's estimate shows no gap at the digits printed, within the range that was stated.
By their numbers in this assay, from the lowest: compounds 1, 2, 3 and 4 (each within the scatter of the next).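

In this assay, isopropyl in place of 2-methoxyethoxy on an aromatic carbon, para to a large group, gives no change at the digits printed from compound 3 to compound 4 (within the scatter), so at this place a group of carbon only reads the same as a chain that holds oxygen. The same compound set against the fluorinated aryl groups gives no change at the digits printed from compound 2 to compound 4 (within the scatter) and no change at the digits printed from compound 1 to compound 4 (within the scatter), so the flat reading now also spans a change from 2,6-difluorophenyl or 2,5-difluorophenyl to 4-isopropylphenyl. Nothing on hand accounts for this flat reading.

Whether any group on this aromatic ring can lift the read-out above the scatter stays open, since all the aryl groups shown read alike. As far as these compounds go, an amine or a carboxylic acid at this place, or a longer chain, would test that, and changes to the shared core itself remain untested here.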